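The source may report more compounds than this note shows. Statements on the series, on what has been measured and on what is new or still open speak of the compounds shown alone.

Compound 1 `Nc1cc(N)c2nc(-c3ccccc3)c(NCc3ccc(Cl)c(Cl)c3)nc2c1` gives 13200 nM in a functional assay on CAKI-1 cells (Homo sapiens) for inhibition, read by sulforhodamine B assay, with a stated time of 48 h (a lower number here means a stronger inhibitor of growth, a higher number a weaker inhibitor of growth), the lowest of the two numbers recorded. Its nearest neighbour is compound 3 `Nc1cc(N)c2nc(-c3ccccc3)c(Sc3ccc(Cl)c(Cl)c3)nc2c1`, which gives 15100 nM, a gap that sits within the scatter. Compound 2 `Nc1cc(N)c2nc(-c3ccccc3)c(Sc3ccc(F)cc3)nc2c1` gives only a limit, < 100000 nM. Among the compounds with values here, the one measured step, a step that the limit leaves unreadable from compound 2 to compound 3, therefore cannot be read in size because of the limit of < 100000 nM in this assay, at which 1 of the 3 values shown sits.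

Compound 4 `COc1ccc(CNc2nc3cc(N)cc(N)c3nc2-c2ccccc2)cc1` differs from compound 1 by 4-methoxyphenyl in place of 3,4-dichlorophenyl on a saturated chain carbon bound to a nitrogen on an aromatic ring. No readable step bears on a change of this kind, so the expectation rests on compound 1 alone. Compound 4 is estimated at 25000 nM, within a range of 8000 nM to 80000 nM, which would mean a step of a 1.9-fold higher number from compound 1 to compound 4 (0.28 log units; within the scatter) toward weaker growth inhibition.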

Compound 4, concentration for 50% growth inhibition: 16200 nM
Beside the measured number, compound 4's estimate is 1.5-fold (0.19 log units) above it; the measured number falls inside the stated range.
By their numbers in this assay, from the lowest: compounds 1, 3 and 4 (each within the scatter of the next).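

In this assay, within the data shown here, 4-methoxyphenyl in place of 3,4-dichlorophenyl on this saturated chain carbon gives a 1.2-fold higher number from compound 1 to compound 4 (0.09 log units; within the scatter) and is the first readable step at this position. The two chlorines can therefore give way to a methoxy group without a change that stands out from the scatter. Nothing measured here gives a reason for this result.

What the compounds shown leave open is how an amine or a carboxylic acid on this ring would read in this assay. On these data alone, a longer chain in place of the single saturated carbon also remains untested among them.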